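The source may hold more compounds than are shown below. What is called first, only, known or untested is meant among the compounds shown, and "the series" means these compounds.

Measured in an ADME assay on Caecum (Rattus norvegicus, strain Sprague-Dawley) for metabolic stability, read by LC-MS, tested at 10 uM (on this read-out higher numbers stand for a longer-lived compound and lower numbers for a shorter-lived compound), so far:
- compound 1 `C[C@@H](N[C@H]1CCN(c2ccc(C(=O)NCCCCNC(CO)(CO)CO)cc2)C1)c1cccc2ccccc12` gives 8 h
- compound 2 `C[C@@H](N[C@H]1CCN(c2ccc(C(=O)NCCS(=O)(=O)O)cc2)C1)c1cccc2ccccc12` gives 0.8 h

Compound 2 at 0.8 h is the lower of the two numbers. Not yet measured is compound 3 `C[C@@H](N[C@H]1CCN(c2ccc(C(=O)NCCCN3CCC(C(=O)O)CC3)cc2)C1)c1cccc2ccccc12` with the change (4-carboxypiperidin-1-yl)methyl in place of sulfo on a saturated chain carbon, two bonds along the chain from an amide-type nitrogen from compound 2: (4-carboxypiperidin-1-yl)methyl in place of sulfo on a saturated chain carbon, two bonds along the chain from an amide-type nitrogen. Among the compounds with values here, the one measured step at this place is a 10-fold lower number from compound 1 to compound 2 (1.00 log units; beyond the scatter) and it is modest. With sulfo gone but the group of compound 1 not restored, a smaller rise is expected in this assay on that single step. The expected step is a 3.8-fold higher number from compound 2 to compound 3 (0.57 log units; beyond the scatter) in size. For compound 3 the estimate is 3 h with 0.9 h to 10 h as expected range.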

Compound 3, half-life: > 12 h
Compound 3: no number, only a limit; the forecaster's own chance of this, stated with the estimate: 5%; middle value at least 4.0-fold (0.60 log units) away from the limit.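

In this assay the reading for compound 3 is a limit, not a number: the limit of > 12 h in this assay, at which 1 of the 3 values shown sits. On a saturated chain carbon, two bonds along the chain from an amide-type nitrogen, (4-carboxypiperidin-1-yl)methyl in place of sulfo gives an at least 15-fold higher number from compound 2 to compound 3 (1.17 log units; beyond the scatter), so a carboxylic acid at the end of this chain does not bring the low reading seen with sulfo. The second step, an at least 1.5-fold higher number from compound 1 to compound 3 (0.17 log units; that floor lies within the scatter), rests on a floor only, so it sets no order. Open, going by these compounds, is whether the ring or the carboxylic acid accounts for the rise; an unsubstituted piperidine or an open-chain amino acid here would separate the two.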